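Swapping the ring amine on a dithiocarbamate for diethylamine

The source may report more compounds than this note shows. Statements on the series, on what has been measured and on what is new or still open speak of the compounds shown alone.

Of the compounds shown here, three have so far been tested in a functional assay on the whole organism for inhibition, with Cicer arietinum as the target, with a stated time of 7 days; a lower number here means a stronger inhibitor, a higher number a weaker inhibitor. Compound 1 `S=C(SCc1nc2ccccc2[nH]1)N1CCCC1` gives 1800 nM, compound 2 `CCCNC(=S)SCc1nc2ccccc2[nH]1` gives 2290 nM, and compound 3 `O=C(CC(SC(=S)N1CCCC1)c1ccccc1)c1ccccc1` gives 1670 nM. The number for compound 3 is the lowest of the three, but it sits within the scatter of both compound 1 and compound 2, so no order among them can be read from these data.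

Compound 4 `CCN(CC)C(=S)SC(CC(=O)c1ccccc1)c1ccccc1` differs from compound 3 by one change: diethylamino in place of pyrrolidin-1-yl on a thiocarbonyl carbon. The one measured step that bears on this is the change at the same thiocarbonyl carbon in the other series, a 1.3-fold higher number from compound 1 to compound 2 (0.10 log units; within the scatter), where an open-chain amine replaced pyrrolidin-1-yl without moving the number beyond the scatter. On that basis the step from compound 3 to compound 4 is expected to be small in this assay, with no direction that can be called, which gives an expected 1.0-fold higher number from compound 3 to compound 4 (0.01 log units; within the scatter). Compound 4 is therefore estimated at 1700 nM, with a range from 700 nM to 4000 nM.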

Compound 4, half-maximal inhibitory concentration: 1840 nM
Beside the measured number, compound 4's estimate is 1.1-fold (0.03 log units) below it; the measured number falls inside the stated range.
By their numbers in this assay, from the lowest: compounds 3, 1, 4 and 2 (each within the scatter of the next).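

In this assay, the ring of pyrrolidin-1-yl gives way to the open diethylamino group of the same heavy-atom count, with a 1.1-fold higher number from compound 3 to compound 4 (0.04 log units; within the scatter), so the ring at this thiocarbonyl carbon makes no readable difference in the series of compound 3. Until now, the only such exchange lay in the other series, with a 1.3-fold higher number from compound 1 to compound 2 (0.10 log units; within the scatter), and the two shared cores now agree that an open-chain amine in place of pyrrolidin-1-yl stays within the scatter, with neither pair going against this. No supporting data are available to account for this result.

The compounds shown leave open whether a much longer chain, such as dioctylamino, would stay equally close at this carbon. They also leave open whether a ring amine with a second hetero atom, such as morpholin-4-yl, would do so.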